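From a Silyl Alkyne to an Alkenyl Chain

The compounds below may be only part of what the source reports. "The series", "measured", "known", "first", "only" and "open" are said of these compounds alone.

The three measured compounds share one core. Compound 1 `CC(=O)Nc1nc(-c2cccc(NS(=O)(=O)c3ccc(C#CC4CCCCC4)cc3)c2)cs1` carries a cyclohexyl group on the triple-bonded carbon, compound 2 `CC(=O)Nc1nc(-c2cccc(NS(=O)(=O)c3ccc(C#C[Si](C)(C)C)cc3)c2)cs1` carries a trimethylsilyl group there, and compound 3 `C#Cc1cccc(S(=O)(=O)Nc2cccc(-c3csc(NC(C)=O)n3)c2)c1` has the bare terminal alkyne. In a functional assay on A-375 cells (Homo sapiens) for antiproliferative activity, read by trypan blue exclusion, with a stated time of 48 h, tested at 10 uM (a higher number here means a weaker effect of the compound at the concentration tested, a lower number a stronger effect), compound 1 gives 1.2%. In this assay compound 3 gives 18.6%. For compound 2 this assay reports only a limit, < 1%, so compound 2 stands at the reporting limit rather than at a number; this is the point described by the limit of < 1% in this assay, at which 1 of the 3 values shown sits. For the measured compounds named here, the one measured step, a number at least 0.2 percentage points lower from compound 1 to compound 2 (that floor lies within the scatter), is small. Compound 4 `CCCCCC/C=C\c1ccc(S(=O)(=O)Nc2cccc(-c3csc(NC(C)=O)n3)c2)cc1` is not yet measured and differs from compound 2 as follows: a group of 8 heavy atoms (8 carbon; no ring) in place of a group of 6 heavy atoms (5 carbon, 1 silicon; no ring), on an aromatic carbon. Going by the values given here, no measured step exchanges the whole alkynyl unit for a chain on that aromatic carbon, so the step from compound 1 to compound 2 bears on it only indirectly, showing that two different groups on the triple-bonded carbon both sat low. Compound 3, with nothing beyond the alkyne, sat higher. Compound 4 keeps a sizable group on that aromatic carbon, so its step of a number at least 2 percentage points higher from compound 2 to compound 4 (that floor lies within the scatter) is expected to be modest and upward from the limit. The estimate for compound 4 in this assay is 3%, between 0.5% and 15%.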

Compound 4, a percentage reported as activity, at one concentration (the size of the read-out at that concentration, not a potency): <= 1%
Compound 4: only a limit was reported; the forecaster's own chance of this, stated with the estimate: 25%; middle value at least 2 percentage points away from the limit.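

For compound 4, this assay reports <= 1%, which is a limit and not a number: the limit of <= 1% in this assay, at which 1 of the 4 values shown sits.

The earlier compounds shown here all carried a triple bond on the aromatic carbon para to a large group, and compound 4 shows that a reading at the reporting limit does not depend on that triple bond, since an eight-carbon chain with a double bond outside aromatic rings stands there instead. The step to the cyclohexyl compound, a number at least 0.2 percentage points lower from compound 1 to compound 4 (that floor lies within the scatter), gives no order between the two, and the step between compound 2 and compound 4 cannot be read, as both ends are limits.

As far as these compounds go, whether a saturated octyl chain, a shorter propyl chain or a chain ending in a carboxylic acid or an amine would also read this low on that aromatic carbon stays open. From the compounds shown here alone, with two of the four compounds at a limit, how far the alkenyl chain and the trimethylsilyl alkyne lie apart also stays open, as does whether either could be told from the cyclohexyl alkyne.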